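The compounds below may be only part of what the source reports. "The series", "measured", "known", "first", "only" and "open" are said of these compounds alone.

Compound 1 `C/N=C(/S)[C@]1(c2cccnc2)CCCC[S@@+]1[O-]`: 700 nM; 400 nM; > 30000 nM (3 entries)
Compound 2 `C/N=C(\S)[C@]1(c2ccns2)CCCC[S+]1[O-]`: 7000 nM
Compound 3 `CC/N=C(\S)[C@]1(c2cccnc2)CCCC[S+]1[O-]`: 300 nM

In a functional assay (aorta) for inhibition, with Rattus norvegicus as the target (on this read-out higher numbers stand for weaker inhibition and lower numbers for stronger inhibition), compound 3 gives 300 nM, the lowest of the two single numbers. Compound 2 gives 7000 nM, a number far higher than that of compound 3 and beyond the scatter. Compound 1 has several entries in this assay, (the several entries of compound 1 in this assay, 700 nM; 400 nM; > 30000 nM (3 entries)). One of the entries for compound 1 is a limit of the assay and not a number.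

Compound 4 `C/N=C(\SC)[C@]1(c2cccnc2)CCCC[S+]1[O-]` differs from compound 3 by a group of 5 heavy atoms (3 carbon, 1 nitrogen, 1 sulfur; no ring) in place of a group of 5 heavy atoms (3 carbon, 1 nitrogen, 1 sulfur; no ring), on a saturated ring carbon. The group that leaves carries the only hydrogen-bond donor; the group that enters carries none. Among the measured compounds shown here, no measured pair among the compounds above makes this kind of change, so the expected size rests on the structures alone. The expectation is that inhibition weakens, by a step clearly beyond the scatter. The expected step is a 10-fold higher number from compound 3 to compound 4 (1.00 log units; beyond the scatter). For compound 4 in this assay the estimate is 3000 nM, with a range from 600 nM to 20000 nM.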

Compound 4, concentration for 90% inhibition: > 30000 nM
Compound 4 was reported as a limit (the forecaster's own chance of this, stated with the estimate: 15%); middle value at least 10-fold (1.00 log units) from the limit.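

Among the compounds shown, this is the first single change at this place, on a saturated ring carbon next to the ring sulfur, and in this assay it comes with an at least 100-fold higher number from compound 3 to compound 4 (2.00 log units; beyond the scatter). The two groups hold the same atoms joined differently, the one that leaves with 1 hydrogen-bond donor and the one that enters with 0 hydrogen-bond donors, so the same atoms at this place do not by themselves keep the inhibition. Compound 4 gives > 30000 nM, which is a limit of the assay and not a number.

The compounds shown leave open whether a carbonyl with an amide hydrogen, in place of the sulfur group, would keep the inhibition seen with compound 3. They also leave open how firm single readings are in this assay, as one compound's entries spread widely: the several entries of compound 1 in this assay, 700 nM; 400 nM; > 30000 nM (3 entries)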